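The source may hold more compounds than are shown below. What is called first, only, known or untested is meant among the compounds shown, and "the series" means these compounds.

Compound 2 `COc1ccc(NC(=O)Nc2cccc(-c3nc(-c4ccc(NC(=O)c5cccnc5)cc4Cl)no3)c2)cc1C(F)(F)F` is one of two compounds of a shared core that have been tested in a functional assay on MDA-MB-231 cells (Homo sapiens) for antiproliferative activity, read by MTT assay, with a stated time of 72 h; on this read-out lower numbers stand for stronger inhibition and higher numbers for weaker inhibition. In this assay compound 2 gives 1700 nM, the lowest of the two numbers, and compound 1 `COc1ccc(NC(=O)Nc2cccc(-c3nc(-c4ccc(NC(=O)c5cccnc5)cc4Cl)no3)c2)cc1` gives 3000 nM. Among the measured compounds shown here, the single step between them, a 1.8-fold lower number from compound 1 to compound 2 (0.25 log units; within the scatter), falls within the usual scatter, so the two values cannot be told apart.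

Compound 3 `C#Cc1cccc(NC(=O)Nc2cccc(-c3nc(-c4ccc(NC(=O)c5cccnc5)cc4Cl)no3)c2)c1` has not yet been measured. It differs from compound 2 in one place: 3-ethynylphenyl in place of 4-methoxy-3-(trifluoromethyl)phenyl on an amide-type nitrogen. For the measured compounds named here, no measured step touches this kind of exchange; the only step known, a 1.8-fold lower number from compound 1 to compound 2 (0.25 log units; within the scatter), concerns a trifluoromethyl in place of hydrogen on the same aryl group and is itself within the scatter. What can be said is that a change at this aryl group has so far left the read-out of this assay where it was. On that slender footing compound 3 is expected to show a step of a 1.5-fold higher number from compound 2 to compound 3 (0.17 log units; within the scatter), that is no move beyond the scatter, with a wide range because only a 1.8-fold lower number from compound 1 to compound 2 (0.25 log units; within the scatter) is available as a guide. Compound 3 is therefore estimated at 2500 nM, between 800 nM and 8000 nM.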

Compound 3, half-maximal inhibitory concentration: > 10000 nM
Compound 3: no number, only a limit (the forecaster's own chance of this, stated with the estimate: 5%); middle value at least 4.0-fold (0.60 log units) away from the limit.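

Compound 3 gives no number in this assay, only a limit of the assay: the limit of > 10000 nM in this assay, at which 1 of the 3 values shown sits.

Even so, the result shows what the earlier pair could not: the aryl group on this amide-type nitrogen can move the read-out beyond the scatter. The exchange of 4-methoxy-3-(trifluoromethyl)phenyl for 3-ethynylphenyl gives an at least 5.8-fold higher number from compound 2 to compound 3 (0.76 log units; beyond the scatter), and the exchange of 4-methoxyphenyl for 3-ethynylphenyl gives an at least 3.3-fold higher number from compound 1 to compound 3 (0.52 log units; beyond the scatter). Both steps run the same way, whereas the trifluoromethyl step between the two methoxy-bearing compounds stayed within the scatter, so at this position the exchange of the whole aryl group has counted for more than that single addition.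

The compounds shown do not separate the arrival of the ethynyl group from the loss of the methoxy group, and the full size of both steps remains unknown. From the compounds shown here alone, it also remains open whether a nitrile, a chlorine or a methyl group in place of the ethynyl group, or a 4-methoxy-3-ethynylphenyl group, would bring the read-out back to the level of compound 1 and compound 2.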